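Chalcone series: methyl capping of the phenolic hydroxy

The source may hold more compounds than are shown below. What is called first, only, known or untested is meant among the compounds shown, and "the series" means these compounds.

Measured so far in an assay on isolated protein for inhibition of lysosomal alpha-glucosidase (Rattus norvegicus), read by spectrophotometry, with a stated time of 5 min, tested at 25 ug/mL; on this read-out higher numbers stand for more inhibition at the one concentration tested (going by the name of the read-out) and lower numbers for less inhibition:
compound 1 `O=C(/C=C/c1ccccc1)c1ccc2occc2c1O` gives 20.8%
compound 2 `O=C(/C=C/c1ccc(O)cc1)c1ccc2occc2c1O` gives 65.7%
compound 3 `O=C(/C=C/c1ccc(O)c(O)c1)c1ccc2occc2c1O` gives 61.5%

Compound 2 holds the highest of the three numbers in this assay, but compound 3 lies within the scatter of it, so no order between those two can be read; only compound 1 lies clearly lower. Among the compounds with values here, the one large step in the set is a number 44.9 percentage points higher from compound 1 to compound 2 (beyond the scatter), which accompanies hydroxy in place of hydrogen on an aromatic carbon. The second such change, a number 4.2 percentage points lower from compound 2 to compound 3 (within the scatter), brings nothing beyond the scatter.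

Compound 4 `COc1ccc(/C=C/C(=O)c2ccc3occc3c2O)cc1` is the next case. Relative to compound 2 the change is methyl in place of hydrogen on an oxygen on an aromatic ring. Within the data shown here, no measured step covers a methyl entering on an oxygen, so the only guide is the step from compound 1 to compound 2: the gain came with the hydroxy, and compound 4 carries that oxygen but without its hydrogen. A downward step is therefore expected, though not necessarily all the way back to the number of compound 1; the step from compound 2 to compound 3 gives no help here.

For compound 4 in this assay the estimate is 35%, with a range from 15% to 58%. This estimate corresponds to an expected step of a number 30.7 percentage points lower from compound 2 to compound 4 (beyond the scatter), expected to lie beyond the scatter.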

Compound 4, a percentage reported as inhibition, at one concentration (the size of the read-out at that concentration, not a potency): 94.8%
Beside the measured number, compound 4's estimate is 59.8 percentage points below it, and the stated range ends below it.
By their numbers in this assay, from the lowest: compound 1; then compounds 3 and 2 (each within the scatter of the next); then compound 4.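

In this assay, methyl in place of hydrogen on this oxygen comes with a number 29.1 percentage points higher from compound 2 to compound 4 (beyond the scatter), so the hydrogen of the hydroxy is not required for inhibition at the one concentration tested, and capping it does not undo the gain over compound 1. The methoxy group comes with a number 74 percentage points higher from compound 1 to compound 4 (beyond the scatter), which exceeds a number 44.9 percentage points higher from compound 1 to compound 2 (beyond the scatter) that accompanied hydroxy at the same place, so at this position the oxygen substituent's identity matters and methoxy gives the highest number of the four compounds. No measurement at hand bears on why the methyl raises the number.

From the compounds shown here alone, it remains open whether the rise continues with a longer chain on the oxygen, such as ethoxy, or holds when an amine or a fluorine stands in place of the methoxy, and whether a methyl on either hydroxy of compound 3 acts in the same way. Going by these compounds, the read-out gives the size of inhibition at a single concentration, so the potency of compound 4 also remains open.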